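Side-chain hydroxyl on the piperidine: what to expect for compound 4

This account rests on a few compounds, and the source may have more. Where it says the series, first, only, none or still open, it means among the compounds named here.

Compound 1 `O=C1c2c[n+]([O-])c3ccccc3c2C(=O)c2c1c1ccccc1n2CCCCN1CCCCC1` gives 200 nM in a functional assay on HCT-116 cells (Homo sapiens) for cytotoxicity, read by MTT assay, with a stated time of 72 h; on this read-out higher numbers stand for weaker inhibition and lower numbers for stronger inhibition.
Compound 2 `O=C1c2c[n+]([O-])c3ccccc3c2C(=O)c2c1c1ccccc1n2Cc1cn([C@H]2C[C@H](O)[C@@H](CO)O2)nn1` gives 120 nM in this assay.
Compound 3 `O=C1c2c[n+]([O-])c3ccccc3c2C(=O)c2c1c1ccccc1n2Cc1cn([C@@H]2O[C@H](CO)[C@@H](O)[C@H](O)[C@H]2O)nn1` gives 130 nM in this assay.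

Compound 1 has the highest of the three numbers, yet its distance to compound 3 and to compound 2 lies within the scatter, so no order among the three can be read. Among the measured compounds shown here, the single one-place step measured, a 1.1-fold higher number from compound 2 to compound 3 (0.03 log units; within the scatter), concerns a ring attached to an aromatic nitrogen and does not bear on the change from compound 1 to compound 4 `O=C1c2c[n+]([O-])c3ccccc3c2C(=O)c2c1c1ccccc1n2CCCN1CCC(O)CC1`, which is 4-hydroxypiperidin-1-yl in place of (piperidin-1-yl)methyl on a saturated chain carbon, three bonds along the chain from an aromatic nitrogen. For the measured compounds named here, with no measured step touching this change, nothing beyond the scatter is expected in this assay. Compound 4 is therefore estimated at 200 nM, between 100 nM and 400 nM, expected as no change at the digits printed from compound 1 to compound 4 (within the scatter).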

Compound 4, half-maximal inhibitory concentration: 190 nM
Estimate against measurement, compound 4: 1.1-fold (0.02 log units) above; low and high end bracket the measured number.
By their numbers in this assay, from the lowest: compounds 2, 3, 4 and 1 (each within the scatter of the next).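

In this assay, replacing 4-(piperidin-1-yl)butyl with 3-(4-hydroxypiperidin-1-yl)propyl gives a 1.1-fold lower number from compound 1 to compound 4 (0.02 log units; within the scatter). This side chain can therefore take a hydroxyl on the piperidine ring and lose one chain carbon with no readable change in this cell test. No available evidence explains this result. Both changes came together, so the step cannot show what each does alone. Going by these compounds, a 4-aminopiperidin-1-yl group, a carboxylic acid on the piperidine ring, or a longer chain carrying the 4-hydroxypiperidin-1-yl group all remain open.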